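Acetamido in place of chloro

The compounds below may be only part of what the source reports. "The series", "measured", "known", "first", "only" and "open" are said of these compounds alone.

In a functional assay on MCF7 cells (Homo sapiens) for antiproliferative activity, read by sulforhodamine B assay, with a stated time of 72 h (on this read-out higher numbers stand for weaker inhibition and lower numbers for stronger inhibition), compound 1 `CC(C)C[C@H](NC(=O)CCSc1cc(NS(=O)(=O)c2ccccc2)c2ccccc2c1O)B(O)O` gives 7460 nM and compound 2 `CC(C)C[C@H](NC(=O)CCSc1cc(NS(=O)(=O)c2ccc(Cl)cc2)c2ccccc2c1O)B(O)O` gives 6910 nM as its reading. Compound 2 therefore stands level with compound 1, the two values lying within the usual scatter of repeat measurements. Compound 3 `CC(=O)Nc1ccc(S(=O)(=O)Nc2cc(SCCC(=O)N[C@@H](CC(C)C)B(O)O)c(O)c3ccccc23)cc1` has not yet been measured. It carries acetamido in place of chloro on an aromatic carbon, para to a large group (acetamido in place of chloro on an aromatic carbon). Going by the values given here, the one measured step that bears on this change is chloro in place of hydrogen on an aromatic carbon (a 1.1-fold lower number from compound 1 to compound 2 (0.03 log units; within the scatter)), and it stayed within the scatter. That single step says little about acetamido, so the range must stay wide. In this assay the expected outcome is a shift no larger than the scatter, in neither direction (a 1.0-fold higher number from compound 2 to compound 3 (0.01 log units; within the scatter)). Compound 3 is estimated at 7000 nM in a range from 3000 nM to 16000 nM for this measurement.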

Compound 3, half-maximal inhibitory concentration: 6620 nM
Compound 3: middle estimate off by 1.1-fold (0.02 log units), on the high side; measured number inside the range.
By their numbers in this assay, from the lowest: compounds 3, 2 and 1 (each within the scatter of the next).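

In this assay, acetamido in place of chloro on this aromatic carbon, para to a large group, gives a 1.0-fold lower number from compound 2 to compound 3 (0.02 log units; within the scatter), and acetamido in place of the hydrogen of compound 1 gives a 1.1-fold lower number from compound 1 to compound 3 (0.05 log units; within the scatter). The earlier step had tested only a single chlorine atom here, whereas acetamido brings 4 heavy atoms, a hydrogen-bond donor and a hydrogen-bond acceptor, and the reading still stays within the scatter across all three compounds. Nothing available explains why the reading holds steady across these changes.

On these data alone, whether an amine or a carboxylic acid at this position would move the reading beyond the scatter remains open. So does the effect of a longer chain, such as a propionamido group, in the place of acetamido.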